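A few compounds are considered here, and "the series" means these few. Any claim that something is new, unique, unknown or untested is made for them only; others in the source may bear on it.

Measured compounds:
- compound 1, `C[C@H](NC(=O)C(=O)Nc1ccccc1)C(=O)N[C@@H](CC(=O)O)C(=O)COc1c(F)c(F)cc(F)c1F`, 670 nM
- compound 2, `C[C@H](NC(=O)C(=O)Nc1ccccc1C(F)(F)F)C(=O)N[C@@H](CC(=O)O)C(=O)COc1c(F)c(F)cc(F)c1F`, 61 nM

In a functional assay on Jurkat cells (Homo sapiens) for inhibition (on this read-out lower numbers stand for stronger inhibition and higher numbers for weaker inhibition), compound 2 stands lowest of the two, the nearest being compound 1 with its higher number. For the measured compounds named here, the one known step, an 11-fold lower number from compound 1 to compound 2 (1.04 log units; beyond the scatter), was large. Compound 3, `C[C@H](NC(=O)C(=O)Nc1ccccc1Cc1ccccc1)C(=O)N[C@@H](CC(=O)O)C(=O)COc1c(F)c(F)cc(F)c1F`, carries the change benzyl in place of trifluoromethyl on an aromatic carbon: a larger group, but again without hydrogen-bond donors or acceptors, at the same place. Going by the values given here, no measured step covers this exchange, so the direction is open. Compound 3 is expected to stay near compound 2, with a 1.5-fold higher number from compound 2 to compound 3 (0.17 log units; within the scatter) not beyond the scatter. The estimate for compound 3 is 90 nM, range 25 nM to 350 nM.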

Compound 3, half-maximal inhibitory concentration: 10 nM
Beside the measured number, compound 3's estimate is 9.0-fold (0.95 log units) above it, outside the stated range (below it).
By their numbers in this assay, from the lowest: compound 3; then compound 2; then compound 1.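

Benzyl in place of trifluoromethyl gives a 6.1-fold lower number from compound 2 to compound 3 (0.79 log units; beyond the scatter) in this assay, so this aromatic carbon accepts a group carrying a six-membered aromatic ring, and the number falls further than it did with trifluoromethyl. Against the unsubstituted compound, benzyl gives a 67-fold lower number from compound 1 to compound 3 (1.83 log units; beyond the scatter). Nothing available explains this gain.

Still open, from the compounds shown here alone, is whether a longer chain ending in phenyl, such as phenethyl, would lower the number further at this place. Also open, going by these compounds, is how an amine or a carboxylic acid on the benzyl ring would change it.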